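The source may report more compounds than this note shows. Statements on the series, on what has been measured and on what is new or still open speak of the compounds shown alone.

Measured compounds in an assay for inhibition of Polyunsaturated fatty acid 5-lipoxygenase (Homo sapiens), read by spectrophotometry, tested at 20 uM; on this read-out lower numbers stand for less inhibition and higher numbers for more inhibition at the one concentration tested (going by the name of the read-out):
- compound 1 `COc1ccc(/C=C/C=C/C=C/C(=O)N2CCCCC2)cc1` gives 1.08%
- compound 2 `COc1cc(/C=C/C=C/C(=O)N2CCCCC2)cc(OC)c1OC` gives 66.7%
- compound 3 `O=C(/C=C/C=C/c1ccc(OC2CCCC2)cc1)N1CCCCC1` gives 16.1%

Compound 3 stands second highest of the three numbers in this assay. Its nearest neighbour is compound 1, whose number is lower by a gap beyond the scatter; furthest from it is compound 2, whose number is higher by a gap well beyond the scatter. Going by the values given here, no two measured compounds differ in a single place, so no step between measured compounds can be counted.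

Compound 4 `O=C(/C=C/C=C/c1ccccc1)N1CCCCC1` has not been measured in this assay. It differs from compound 3 in one place: hydrogen in place of cyclopentyloxy on an aromatic carbon.

Compound 1 carries a methoxy on its ring and sits lowest in this assay, while compound 3 with its cyclopentyloxy sits higher, so stripping the ring down to bare hydrogen is expected to lower the number rather than raise it. The step from compound 3 to compound 4 is expected to be modest, on the order of a number 8.1 percentage points lower from compound 3 to compound 4 (within the scatter), downward, and possibly no larger than the scatter. Compound 4 is accordingly estimated at 8%, within a range of 0% to 25%.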

Compound 4, a percentage reported as inhibition, at one concentration (the size of the read-out at that concentration, not a potency): 36.3%
The estimate for compound 4 lay 28.3 percentage points below the measured number; measured number outside the range, above it.
By their numbers in this assay, from the lowest: compound 1; then compound 3; then compound 4; then compound 2.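

This position on the aromatic carbon, para to a large group, now has its first single-place comparison in this assay: with hydrogen in place of cyclopentyloxy, the step is a number 20.2 percentage points higher from compound 3 to compound 4 (beyond the scatter) and lies beyond the scatter. On this core, the cyclopentyloxy group therefore gives no gain in inhibition at the one concentration tested, and compound 4, with hydrogen at this place, reads higher than compound 3. No available evidence accounts for the step.

Going by these compounds, whether a hydroxy group or an amine at this place would read nearer compound 4 or nearer compound 3 remains open. Also open, on these data alone, is whether the same change gives a step of the same direction on the cores of compound 1 and compound 2.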